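Trifluoromethyl in place of methyl on a salicylanilide

The source may hold more compounds than are shown below. What is called first, only, known or untested is meant among the compounds shown, and "the series" means these compounds.

The compounds here share a core in which a hydroxy-bearing aromatic ring carries an amide linked to a second aromatic ring. Compound 1, `Cc1ccc(C(=O)Nc2ccc(C#N)cc2)c(O)c1`, is the starting point. In a functional assay on KG-1 cells (Homo sapiens) for cytotoxicity, read by luminescence and CellTiter-Glo, with a stated time of 3 days (a higher number here means a weaker inhibitor, a lower number a stronger inhibitor), compound 1 gives 2560 nM. Of the two plain numbers recorded, this is the higher; compound 2, `O=C(Nc1cc(C(F)(F)F)cc(C(F)(F)F)c1)c1cc(Br)c(-c2ccccc2)cc1O`, gives 300 nM, and the gap between the two lies beyond the scatter. Compound 3, `N#Cc1ccc2nc(-c3ccccc3O)[nH]c2c1`, is a different case: its result is a limit of the assay rather than a number, shown as the limit of > 10000 nM in this assay, at which 1 of the 3 values shown sits, and compound 3 stands at > 10000 nM.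

The step considered now leads to compound 4, `N#Cc1ccc(NC(=O)c2ccc(C(F)(F)F)cc2O)cc1`. The change is trifluoromethyl in place of methyl on an aromatic carbon. Among the measured compounds shown here, no pair of measured compounds differs by only this change, so the size of the step is not known from the data. The expectation is a modest gain in potency, with the number for compound 4 falling somewhat below that of compound 1, by a step of a 1.7-fold lower number from compound 1 to compound 4 (0.23 log units; within the scatter). In this assay compound 4 is estimated at 1500 nM, with a likely range from 500 nM to 5000 nM.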

Compound 4, half-maximal inhibitory concentration: 1440 nM
Beside the measured number, compound 4's estimate is 1.0-fold (0.02 log units) above it; the range from low to high includes it.
By their numbers in this assay, from the lowest: compound 2; then compounds 4 and 1 (each within the scatter of the next). At a limit, above all of these: compound 3.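

In this assay, among the compounds shown here, putting trifluoromethyl in place of methyl gives a 1.8-fold lower number from compound 1 to compound 4 (0.25 log units; within the scatter), and this is the first pair of compounds that differ in one place only, so the change can finally be read directly. The step stays inside the usual spread of repeat measurements, which means compound 1 and compound 4 cannot be told apart in this test: on the aromatic carbon meta to a hydroxy group and para to a large group, either group is accepted on this core, at least in this single pair. None of the measurements shown offers an explanation for this result.

On these data alone, whether a different group at this position, such as an amine, a carboxylic acid or a longer alkyl chain, would shift the number beyond that spread remains open. Compound 2 gives 300 nM but differs from compound 4 in several places, and which of those differences goes with its number cannot be read from the compounds shown.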